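A few compounds are considered here, and "the series" means these few. Any claim that something is new, unique, unknown or untested is made for them only; others in the source may bear on it.

Compounds measured: compound 1 `CCCCCCCCCCCCCCCCCC(=O)Nc1nnc(S[C@@H]2O[C@H](COC(C)=O)[C@H](OC(C)=O)[C@H](OC(C)=O)[C@H]2OC(C)=O)s1` gives 23600 nM; compound 2 `CCCCCCCC(=O)Nc1nnc(S[C@@H]2O[C@H](CO)[C@H](O)[C@H](O)[C@H]2O)s1` gives 30800 nM; compound 3 `CCCCCCCCCCCCCCCCCC(=O)Nc1nnc(S[C@@H]2O[C@H](CO)[C@H](O)[C@H](O)[C@H]2O)s1` gives 67100 nM, all in a functional assay on MDA-MB-231 cells (Homo sapiens) for cytotoxicity, read by MTT assay, with a stated time of 24 h; a lower number here means a stronger inhibitor, a higher number a weaker inhibitor.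

Compound 1 has the lowest of the three numbers; its gap to compound 2 lies within the scatter, and only compound 3 stands clearly above it. Compound 4 `CCCCCCCC/C=C\CCCCCCCCCCCC(=O)Nc1nnc(S[C@@H]2O[C@H](COC(C)=O)[C@H](OC(C)=O)[C@H](OC(C)=O)[C@H]2OC(C)=O)s1` differs from compound 1 by dec-1-en-1-yl in place of hexyl on a saturated chain carbon, ten or more bonds along the chain from a carbonyl carbon. For the measured compounds named here, the only measured step touching the chain is a 2.2-fold higher number from compound 2 to compound 3 (0.34 log units; beyond the scatter), a longer chain raising the number modestly. Going by the values given here, no measured step covers the double bond. Compound 4 is therefore expected to sit somewhat higher than compound 1, with a 1.6-fold higher number from compound 1 to compound 4 (0.21 log units; within the scatter) as the expected step, and its estimated value is 38000 nM, within the range 16000 nM to 90000 nM.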

Compound 4, half-maximal inhibitory concentration: 25300 nM
Estimate against measurement, compound 4: 1.5-fold (0.18 log units) above; low and high end bracket the measured number.
By their numbers in this assay, from the lowest: compounds 1, 4 and 2 (each within the scatter of the next); then compound 3.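

In this assay, dec-1-en-1-yl in place of hexyl on a saturated chain carbon, ten or more bonds along the chain from a carbonyl carbon, gives a 1.1-fold higher number from compound 1 to compound 4 (0.03 log units; within the scatter). This change therefore does not separate the two compounds, unlike the earlier chain step, a 2.2-fold higher number from compound 2 to compound 3 (0.34 log units; beyond the scatter). No available evidence accounts for this result.

Because the change brings added chain carbons and a double bond together, the compounds shown cannot separate the two. Also open, from the compounds shown here alone, is how a carboxylic acid or an amine at the chain end would read on the core of compound 1.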